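Chloro for fluoro on the aryl arm of compound 2

The source may report more compounds than this note shows. Statements on the series, on what has been measured and on what is new or still open speak of the compounds shown alone.

Measured compounds in a functional assay on the whole organism (strain Albino) with Mus musculus as the target, with a stated time of 0.5 h; a lower number here means that less compound is needed, a higher number that more compound is needed for the effect:
compound 1 `COc1ccc(-c2cc(-c3ccc(F)cc3)nc(NC(=O)N/N=C\c3ccc([N+](=O)[O-])cc3)n2)cc1OC`, compound 1 gives 100 mg/kg
compound 2 `C/C(=N/NC(=O)Nc1nc(-c2ccc(F)cc2)cc(-c2ccc([N+](=O)[O-])cc2)n1)c1ccc(C)cc1`, compound 2 gives 100 mg/kg
compound 3 `COc1ccc(/C(C)=N\NC(=O)Nc2nc(-c3ccc(F)cc3)cc(-c3ccc([N+](=O)[O-])cc3)n2)cc1`, compound 3 gives 100 mg/kg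

Compound 2 stands level with compound 1 and compound 3 in this assay at the digits shown; all three values fall within the scatter of each other, so no order can be read among them. Within the data shown here, the one single-point step in the set, no change at the digits printed from compound 2 to compound 3 (within the scatter), is a swap on the outer aryl ring and left the read-out unchanged.

Compound 4 `C/C(=N/NC(=O)Nc1nc(-c2ccc(Cl)cc2)cc(-c2ccc([N+](=O)[O-])cc2)n1)c1ccc(C)cc1` differs from compound 2 by chloro in place of fluoro on an aromatic carbon. Among the measured compounds shown here, no measured pair swaps one halogen for another, so the step from compound 2 to compound 3 is the only one that bears, and only by analogy as a small change on a peripheral aromatic carbon. On that basis no step beyond the scatter is expected in this assay for the change from compound 2 to compound 4, that is no change at the digits printed from compound 2 to compound 4 (within the scatter).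

Compound 4 is therefore estimated at 100 mg/kg, with a likely range from 50 mg/kg to 200 mg/kg.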

Compound 4, dose for half-maximal effect: 300 mg/kg
For compound 4 the middle estimate is 3.0-fold (0.48 log units) below the measured one; the whole stated range lies below it.
By their numbers in this assay, from the lowest: compounds 1, 2 and 3 (each within the scatter of the next); then compound 4.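

In this assay, among these compounds, the change from 4-fluorophenyl to 4-chlorophenyl gives a 3.0-fold higher number from compound 2 to compound 4 (0.48 log units; beyond the scatter), so this aryl arm is the first place where a single swap moves the read-out beyond the scatter. The earlier step, no change at the digits printed from compound 2 to compound 3 (within the scatter), involved a swap on the other aryl arm and gave no sign that the series responds to so small a change. Within this one pair, fluoro needs less compound than chloro for the effect, and nothing available here accounts for the difference.

The compounds shown leave open how this position responds to bromo, methoxy or an amine, and whether hydrogen in place of the halogen would read like compound 2 or compound 4. Also open, from the compounds shown here alone, is whether the same halogen swap carries the same step on the core of compound 3.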